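The source may report more compounds than this note shows. Statements on the series, on what has been measured and on what is new or still open speak of the compounds shown alone.

The study compares three measured compounds and one yet to be measured in a physicochemical assay for lipophilicity, read by HPLC, at pH 7.5; a lower number here means a more polar compound, a higher number a more lipophilic compound. Compound 1, `CCOc1ccccc1-c1ccc(-c2nc3cncc(Cl)c3c(N[C@H](CC)C(N)=O)c2C#N)cc1`, gives 3.7 in this assay. Compound 2, `CCOc1ccccc1-c1ccc(-c2nc3cnccc3c(N[C@H](CC)C(=O)N(C)C)c2C#N)cc1`, gives 3.7 in this assay. Compound 3, `CC[C@@H](Nc1c(C#N)c(-c2ccc(-c3cccc(Cl)c3OC)cc2)nc2cnccc12)C(N)=O`, gives 3.1 in this assay, the lowest of the three numbers; both compound 1 and compound 2 stand higher, and each of those gaps lies beyond the usual scatter. Compound 4, `CC[C@@H](Nc1c(C#N)c(-c2ccc(-c3ccccc3Cl)cc2)nc2cnccc12)C(N)=O`, is the unmeasured compound. It differs from compound 3 in one place: 2-chlorophenyl in place of 3-chloro-2-methoxyphenyl on an aromatic carbon. Within the data shown here, no pair of measured compounds differing in a single place is available to calibrate a change of this kind, so the expectation rests on compound 3 alone. With one hydrogen-bond acceptor and two heavy atoms fewer in the group that enters, and no other change to the shared core, the step from compound 3 to compound 4 is expected to be small, no change at the digits printed from compound 3 to compound 4 (within the scatter), and not beyond the scatter in either direction. Compound 4 is therefore estimated at 3.1 in this assay, within a range from 2.7 to 3.5.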

Compound 4, distribution coefficient: 2.9
Beside the measured number, compound 4's estimate is 0.20 log units above it; the measured number falls inside the stated range.
By their numbers in this assay, from the lowest: compounds 4 and 3 (each within the scatter of the next); then compounds 1 and 2 (each within the scatter of the next).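

Exchanging 3-chloro-2-methoxyphenyl for 2-chlorophenyl on an aromatic carbon, para to a large group, gives the only single-place comparison among the compounds shown: in this assay the step is a number 0.20 log units lower from compound 3 to compound 4 (within the scatter). The group that leaves has 9 heavy atoms and 1 hydrogen-bond acceptor, while the group that enters has 7 heavy atoms and 0 hydrogen-bond acceptors, yet this exchange leaves the two compounds indistinguishable in this assay, which compounds 1 and 2, differing from compound 3 in more than one place, could not show. No measurement shown here accounts for this result.

Among these compounds, whether the same exchange would give a step of similar size with the other structural features of compound 1 or compound 2 remains open, since the single step comes from one matched pair on one shared core. Also open, as far as these compounds go, is how this position would read in this assay with a group of a different kind on the six-membered aromatic ring, such as an amine or a carboxylic acid, or with a plain phenyl ring carrying no chlorine at all.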